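The source may hold more compounds than are shown below. What is called first, only, known or untested is meant among the compounds shown, and "the series" means these compounds.

Measured compounds:
Compound 1 `COc1cc(-c2nnc(SCC(=O)Nc3ccc(/C(C)=N/O)cc3)n2-c2ccccc2)cc(OC)c1OC`; in a functional assay on the whole organism (strain albino) for inhibition, with Rattus norvegicus as the target, read by paw edema, with stated times of 30 min and 2 h, at a dose of 0.28 mmol/kg by the oral route (a higher number here means more inhibition at the dose given (going by the name of the read-out), a lower number less inhibition), compound 1 gives 62%.
Compound 2 `CCn1c(SCC(=O)Nc2ccc(/C(C)=N/O)cc2)nnc1-c1ccc(OC)c(OC)c1`; compound 2 gives 65%.
Compound 3 `CCn1c(SCC(=O)Nc2ccc(/C(C)=N/O)cc2)nnc1-c1ccc(OC)cc1`; compound 3 gives 58%.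

Compound 2 stands with the highest of the three numbers, but its gaps to compound 1 and to compound 3 both lie within the scatter, so no order among the three is shown. Compound 4 `CCn1c(SCC(=O)Nc2ccc(/C(C)=N/O)cc2)nnc1-c1cc(OC)c(OC)c(OC)c1` differs from compound 2 by methoxy in place of hydrogen on an aromatic carbon. For the measured compounds named here, the one measured step, a number 7 percentage points lower from compound 2 to compound 3 (within the scatter), took a methoxy away and stayed within the scatter; compound 1, which carries three methoxy groups on a core with a different substituent, gives a number close to that of compound 2. Neither observation points to a step beyond the scatter, so the expected step of a number 2 percentage points lower from compound 2 to compound 4 (within the scatter) is small. Compound 4 is therefore estimated at 63%, in the range 52% to 74%.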

Compound 4, a percentage reported as inhibition, in the whole organism at one dose (the size of the read-out at that dose, not a potency): 49%
Beside the measured number, compound 4's estimate is 14 percentage points above it; measured number outside the range, below it.
By their numbers in this assay, from the lowest: compounds 4, 3, 1 and 2 (each within the scatter of the next, the first and the last beyond it).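

In this assay, for the compounds shown here, the added methoxy, ortho to a methoxy group and meta to a large group, gives the first step on this ring that lies beyond the scatter: a number 16 percentage points lower from compound 2 to compound 4 (beyond the scatter). Going by these compounds alone, with the three methoxy groups held constant, ethyl in place of phenyl on the aromatic nitrogen also counts, a number 13 percentage points lower from compound 1 to compound 4 (beyond the scatter), so the close numbers of the earlier compounds do not carry over to this substitution pattern. Nothing available explains either step. Going by these compounds, whether a hydroxyl or a chlorine at this same position would give a step of this kind stays open, as does the effect of a chain longer than ethyl on the aromatic nitrogen.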